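The source may report more compounds than this note shows. Statements on the series, on what has been measured and on what is new or still open speak of the compounds shown alone.

The three measured compounds share one core and differ only in the aryl group attached to the amide-type nitrogen. Compound 1 `O=C(CSC(=S)N[C@H]1CCOC1=O)Nc1ccccc1F` carries a fluorophenyl there; in a functional assay on SMMC-7721 cells (Homo sapiens) for cytotoxicity, read by MTT assay, with a stated time of 72 h (a lower number here means a stronger inhibitor, a higher number a weaker inhibitor), compound 1 gives only a limit of the assay, > 128000 nM. Compound 2 `O=C(CSC(=S)N[C@H]1CCOC1=O)Nc1ccc(Cl)cc1` carries a chlorophenyl, and in this assay compound 2 likewise gives a limit, > 128000 nM. Among the compounds with values here, compound 3 `Cc1ccc(NC(=O)CSC(=S)N[C@H]2CCOC2=O)cc1` carries a methylphenyl, and in this assay compound 3 gives 32700 nM, the only actual number among the three. The other two sit at the limit of > 128000 nM in this assay, at which 2 of the 3 values shown sit. The steps out of those limits, an at least 3.9-fold lower number from compound 1 to compound 3 (0.59 log units; beyond the scatter) and an at least 3.9-fold lower number from compound 2 to compound 3 (0.59 log units; beyond the scatter), both point the same way, while a step that the two limits leave unreadable from compound 1 to compound 2 cannot be read. Compound 4 `CC(=O)c1ccc(NC(=O)CSC(=S)N[C@H]2CCOC2=O)cc1` is not yet measured; it differs from compound 3 by acetyl in place of methyl on an aromatic carbon. Within the data shown here, no measured step involves an acetyl, so the evidence runs only from chloro or fluoro to methyl. The expectation for compound 4 in this assay is therefore uncertain, with a step of a 1.8-fold higher number from compound 3 to compound 4 (0.26 log units; within the scatter) toward a somewhat higher number. Compound 4 is estimated at 60000 nM, within 20000 nM to 200000 nM.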

Compound 4, half-maximal inhibitory concentration: > 128000 nM
Compound 4 ended at the assay's limit (the forecaster's own chance of this, stated with the estimate: 35%); middle value at least 2.1-fold (0.32 log units) from the limit.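

In this assay, within the data shown here, acetyl in place of methyl on the aromatic carbon gives an at least 3.9-fold higher number from compound 3 to compound 4 (0.59 log units; beyond the scatter), so this position now shows a loss from a change away from methyl, where the earlier steps showed only a gain on reaching it. Methyl now gives a lower number than both chloro and acetyl at this position, so compound 3 is the only compound with an actual number, and the rest of the series sits at one limit: the limit of > 128000 nM in this assay, at which 3 of the 4 values shown sit. The steps between compounds at that limit cannot be read, so chloro and acetyl cannot be ranked against each other.

As far as these compounds go, it remains open whether the gain belongs to methyl alone or would extend to a slightly larger group such as ethyl, or to a methoxy or an amine at the same place. From the compounds shown here alone, with only compound 3 giving a number, the size of any such effect also remains open.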